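Weak cytotoxicity across aryl variants of a shared core

The source may report more compounds than this note shows. Statements on the series, on what has been measured and on what is new or still open speak of the compounds shown alone.

Measured compounds:
- compound 1, `C=CCn1c(=O)/c(=C\c2cccc(Cl)c2)[nH]c(=O)/c1=C\c1ccccc1OC`, 5500 nM
- compound 2, `C=CCn1c(=O)/c(=C\c2ccccc2C(F)(F)F)[nH]c(=O)/c1=C\c1ccccc1OC`, 4600 nM
- compound 3, `C=CCn1c(=O)/c(=C\c2ccc(F)c(Br)c2)[nH]c(=O)/c1=C\c1ccccc1OC`, "not active" (no number reported)

Among the measured compounds shown here, in a functional assay on HeLa cells (Homo sapiens) for cytotoxicity, read by CCK-8 assay, with a stated time of 72 h (a lower number here means a stronger inhibitor, a higher number a weaker inhibitor), compound 1 gives 5500 nM, and compound 2 gives 4600 nM; the one step between them, a 1.2-fold lower number from compound 1 to compound 2 (0.08 log units; within the scatter), is within the scatter. Compound 3 stands apart: in this assay compound 3 is reported as "not active" (no number reported), with no number given, so it cannot be placed on the same scale as compound 1 or compound 2 beyond the statement that it showed no measurable effect.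

Compound 4, `C=CCn1c(=O)/c(=C\c2cc(F)ccc2C)[nH]c(=O)/c1=C\c1ccccc1OC`, differs from compound 3 in one place: 5-fluoro-2-methylphenyl in place of 3-bromo-4-fluorophenyl on a double-bonded chain carbon bound to an aromatic carbon. For the measured compounds named here, no measured step covers this change. Going by the values given here, the only step in hand, from compound 1 to compound 2, concerns a different pair of aryl groups and is within the scatter, so it offers no direction for compound 4. With compound 3 giving no number and the two numbered compounds sitting close together, the expectation for compound 4 in this assay can rest only on the range already seen. Compound 4 is therefore expected to give an estimated 10000 nM, with a range from 3000 nM to 40000 nM, and a real chance that, like compound 3, no number is reported.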

Compound 4, half-maximal inhibitory concentration: 2900 nM
Compound 4: the middle estimate sits 3.4-fold (0.54 log units) above what was measured; the whole stated range lies above it.
By their numbers in this assay, from the lowest: compounds 4, 2 and 1 (each within the scatter of the next).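

With 5-fluoro-2-methylphenyl on a double-bonded chain carbon bound to an aromatic carbon, this assay gives a 1.6-fold lower number from compound 2 to compound 4 (0.20 log units; within the scatter) and a 1.9-fold lower number from compound 1 to compound 4 (0.28 log units; within the scatter), so a third numbered aryl group joins the other two and none of the three can be told apart. Compound 3, with 3-bromo-4-fluorophenyl, is reported as not active, whereas compound 4 gives 2900 nM, which shows that two aryl groups with the same heavy-atom count, one carrying bromine and the other a methyl carbon, can differ in whether a number is reported at all, although any step involving compound 3 cannot be read as a size. Nothing shown here accounts for that difference between compound 3 and compound 4.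

The compounds shown leave open whether an aryl group carrying an amine or a carboxylic acid at this place would give a number clearly apart from those of compound 1, compound 2 and compound 4. They also leave open whether the absence of a number for compound 3 follows from the bromine or from the particular arrangement of its two halogens.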